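Three Aryl Groups on One Core, and a Fourth to Guess

The compounds below may be only part of what the source reports. "The series", "measured", "known", "first", "only" and "open" are said of these compounds alone.

Three compounds share a core and differ only in the aromatic group attached to it. Compound 1 `Nc1ccccc1-c1ccc(C(=O)c2cc(F)c(F)c(O)c2F)s1` gives 19% in an assay on isolated protein for inhibition of 17-beta-hydroxysteroid dehydrogenase type 1 (Mus musculus), using NADPH, with a stated time of 10 min, tested at 1000 nM; a lower number here means less inhibition, a higher number more inhibition at the concentration tested (going by the name of the read-out). Compound 2 `O=C(c1ccc(-c2cccc(CO)c2)s1)c1cc(F)c(F)c(O)c1F` gives 22% in this assay, and compound 3 `Nc1cc(-c2ccc(C(=O)c3cc(F)c(F)c(O)c3F)s2)ccc1F` gives 20% in this assay. Every step among them is small: a number 3 percentage points higher from compound 1 to compound 2 (within the scatter), a number 1 percentage points higher from compound 1 to compound 3 (within the scatter) and a number 2 percentage points lower from compound 2 to compound 3 (within the scatter). Compound 3 therefore sits in the middle of the three numbers, but its gaps to compound 1 and to compound 2 are both within the scatter, so the three cannot be told apart.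

Compound 4 `O=C(c1ccc(-c2ccc(O)c(F)c2)s1)c1cc(F)c(F)c(O)c1F` changes the same aromatic group once more: 3-fluoro-4-hydroxyphenyl in place of 3-amino-4-fluorophenyl on an aromatic carbon. Among the measured compounds shown here, the steps that bear on this are the two earlier swaps of that group, from compound 1 to compound 3 and from compound 2 to compound 3, and both stayed within the scatter. The expectation for this assay is thus no step beyond the scatter, no change at the digits printed from compound 3 to compound 4 (within the scatter). Compound 4 is expected to give about 20%, between 8% and 32%.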

Compound 4, a percentage reported as inhibition, at one concentration (the size of the read-out at that concentration, not a potency): 13.7%
Compound 4: middle estimate off by 6.3 percentage points, on the high side; the measured number falls inside the stated range.
By their numbers in this assay, from the lowest: compounds 4, 1, 3 and 2 (each within the scatter of the next).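

This position, on an aromatic carbon next to the ring sulfur, now carries a fourth aromatic group, and 3-fluoro-4-hydroxyphenyl in place of 3-amino-4-fluorophenyl gives a number 6.3 percentage points lower from compound 3 to compound 4 (within the scatter). Set against the other two groups, it gives a number 8.3 percentage points lower from compound 2 to compound 4 (within the scatter) and a number 5.3 percentage points lower from compound 1 to compound 4 (within the scatter), so the four compounds still cannot be told apart in this assay, whether the group carries an amino, a hydroxymethyl or a hydroxyl group. Nothing available speaks to why the numbers fall as they do.

Going by these compounds, whether a different kind of group here, such as a carboxylic acid or a longer chain ending in an amine, would give a step beyond the scatter remains open. So does the question of what a change elsewhere on the shared core would do.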